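This account rests on a few compounds, and the source may have more. Where it says the series, first, only, none or still open, it means among the compounds named here.

In a physicochemical assay for lipophilicity, measured as octanol-water partition, at pH 7.4 (on this read-out lower numbers stand for lower lipophilicity and higher numbers for higher lipophilicity), compound 1 `Cc1ccc2[nH]c(C(=O)N[C@H]3CN(S(=O)(=O)c4ccccc4)C[C@@H]3C(=O)NCCN(C)C)cc2c1` gives 2.1 and compound 2 `Cc1ccc2[nH]c(C(=O)N[C@H]3CN(S(=O)(=O)c4cnccn4)C[C@@H]3C(=O)NCCN(C)C)cc2c1` gives 1 as the lower of the two numbers. Compound 3 `Cc1ccc2[nH]c(C(=O)N[C@H]3CN(S(=O)(=O)c4cn(C)nc4C)C[C@@H]3C(=O)NCCN(C)C)cc2c1` remains unmeasured and differs from compound 2 by 1,3-dimethyl-1H-pyrazol-4-yl in place of pyrazin-2-yl on a sulfonyl sulfur in that 1,3-dimethyl-1H-pyrazol-4-yl stands in place of pyrazin-2-yl on a sulfonyl sulfur. Within the data shown here, the one measured step at this place is large, a number 1.10 log units lower from compound 1 to compound 2 (beyond the scatter) with pyrazin-2-yl in place of phenyl, and it starts from phenyl rather than pyrazin-2-yl, so it guides the expectation only loosely. A smaller step upward is expected, an estimated a number 0.40 log units higher from compound 2 to compound 3 (beyond the scatter) in this assay here. Compound 3 is estimated at 1.4 with 1 to 1.9 as its range.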

Compound 3, distribution coefficient: 1.4
Estimate against measurement, compound 3: no gap at the digits printed; low and high end bracket the measured number.
By their numbers in this assay, from the lowest: compound 2; then compound 3; then compound 1.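

Putting 1,3-dimethyl-1H-pyrazol-4-yl in place of pyrazin-2-yl on the sulfonyl sulfur gives a number 0.40 log units higher from compound 2 to compound 3 (beyond the scatter) in this assay, and in place of phenyl it gives a number 0.70 log units lower from compound 1 to compound 3 (beyond the scatter), so the five-membered ring falls inside the span set by phenyl and pyrazin-2-yl. These two heteroaromatic groups have the same counts of hetero atoms and hydrogen-bond acceptors, yet their numbers differ beyond the scatter, so in these compounds those counts alone do not fix the read-out at this place. Nothing available explains these steps. The compounds shown leave open how much of the step belongs to the two methyl groups rather than the ring, which an unsubstituted pyrazol-4-yl would address. Going by these compounds, how a phenyl carrying a carboxylic acid would read here also remains open.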